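The source may hold more compounds than are shown below. What is called first, only, known or untested is meant among the compounds shown, and "the series" means these compounds.

Series notes. Compound 1 `COc1ccccc1/C=C(/SCc1ccc(Cl)cc1)C(=O)c1ccc(Cl)cc1` gives 1000 nM in a functional assay on DU-145 cells (Homo sapiens) for inhibition, read by trypan blue exclusion, with a stated time of 96 h; a lower number here means a stronger inhibitor of growth, a higher number a weaker inhibitor of growth. Within the data shown here, compound 2 `Cc1ccc(/C=C(/SCc2ccc(Cl)cc2)C(=O)c2ccc(Cl)cc2)s1` gives 50000 nM, and the step of a 50-fold higher number from compound 1 to compound 2 (1.70 log units; beyond the scatter) is the only measured step in which one group replaces another. Compound 3 `COc1ccc(/C=C(/SCc2ccc(Cl)cc2)C(=O)c2ccc(C(=O)O)cc2)cc1` gives 10000 nM, the second highest of the three numbers; against compound 2 it reads lower, against compound 1 higher, both beyond the scatter. Compound 4 `COc1ccc(/C=C(/SCc2ccc(Cl)cc2)C(=O)c2ccc(Cl)cc2)cc1` differs from compound 3 in one place: chloro in place of carboxy on an aromatic carbon. Among the measured compounds shown here, no measured step covers this exchange on the benzoyl ring, so the expectation rests on compound 1, which carries the same chloro group and gives 1000 nM. For compound 4 a lower number is therefore expected, the step of a 5.0-fold lower number from compound 3 to compound 4 (0.70 log units; beyond the scatter). Compound 4 is estimated at 2000 nM, within 500 nM to 10000 nM.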

Compound 4, concentration for 50% growth inhibition: 10000 nM
For compound 4 the middle estimate is 5.0-fold (0.70 log units) below the measured one; low and high end bracket the measured number.
By their numbers in this assay, from the lowest: compound 1; then compounds 3 and 4 (each within the scatter of the next); then compound 2.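

Working notes: at this aromatic carbon, para to a large group, chloro in place of carboxy gives no change at the digits printed from compound 3 to compound 4 (within the scatter) and so does not separate 4-carboxyphenyl from 4-chlorophenyl. On the double-bonded chain carbon, 4-methoxyphenyl in place of 2-methoxyphenyl gives a 10-fold higher number from compound 1 to compound 4 (1.00 log units; beyond the scatter) and 4-methoxyphenyl in place of 5-methylthiophen-2-yl gives a 5.0-fold lower number from compound 2 to compound 4 (0.70 log units; beyond the scatter) in the same series. No measured evidence bears on the cause of these readings. As far as these compounds go, whether an amine at the aromatic carbon would read alike stays open. Also open, from the compounds shown here alone, is whether 2-methoxyphenyl keeps its lower number with carboxy in place of chloro.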